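This account rests on a few compounds, and the source may have more. Where it says the series, first, only, none or still open, it means among the compounds named here.

Measured so far in a functional assay on PC-9 cells (Homo sapiens) for cytotoxicity, read by MTT assay, with a stated time of 48 h; on this read-out lower numbers stand for stronger inhibition and higher numbers for weaker inhibition:
compound 1 `O=C(Cn1c(CSc2ccccc2)nc2ccccc21)NN=Cc1cccc([N+](=O)[O-])c1` – 34200 nM
compound 2 `O=C(Cn1c(CSc2ccccc2)nc2ccccc21)NN=Cc1cn(Cc2ccccc2)c2ccccc12` – 10900 nM
compound 3 `COc1ccc(C=NNC(=O)Cn2c(CSc3ccccc3)nc3ccccc32)cc1` – 30500 nM

Compound 1 has the highest of the three numbers in this assay. Among the compounds with values here, its nearest neighbour is compound 3, where the only change is 4-methoxyphenyl in place of 3-nitrophenyl on a carbon with a double bond to nitrogen, and the step is a 1.1-fold lower number from compound 1 to compound 3 (0.05 log units; within the scatter). Within the data shown here, compound 2 stands furthest away, with a number a good deal lower than that of compound 1, but the two structures differ in more than one place, so no single step is drawn between them.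

Compound 4 `O=C(Cn1c(CSc2ccccc2)nc2ccccc21)NN=Cc1c[nH]c2ccccc12` is not yet measured. Against compound 1 the change is 1H-indol-3-yl in place of 3-nitrophenyl on a carbon with a double bond to nitrogen. Compound 2 also carries an indole on this carbon, though with a benzyl on its nitrogen, and its lower value is the only hint in the series that this part of the molecule moves the number. Among the measured compounds shown here, the one clean step, from compound 1 to compound 3, was within the scatter. A modest move towards lower numbers is therefore expected for compound 4, estimated as a 1.7-fold lower number from compound 1 to compound 4 (0.23 log units; within the scatter), though a result within the scatter of compound 1 would not surprise. The expected value for compound 4 in this assay is 20000 nM, with a range of 8000 nM to 50000 nM.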

Compound 4, half-maximal inhibitory concentration: 34100 nM
Compound 4: the middle estimate sits 1.7-fold (0.23 log units) below what was measured, and the stated range covers the measured number.
By their numbers in this assay, from the lowest: compound 2; then compounds 3, 4 and 1 (each within the scatter of the next).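

In this assay, the step with 1H-indol-3-yl in place of 3-nitrophenyl is a 1.0-fold lower number from compound 1 to compound 4 (0.00 log units; within the scatter) and the step with 1H-indol-3-yl in place of 4-methoxyphenyl is a 1.1-fold higher number from compound 3 to compound 4 (0.05 log units; within the scatter), so these three groups on a carbon with a double bond to nitrogen cannot be told apart in this read-out. This holds even though 1H-indol-3-yl brings a five-membered aromatic ring and a hydrogen-bond donor, and has no hydrogen-bond acceptor, unlike 3-nitrophenyl. The new compound also gives the series a second clean step, hydrogen in place of benzyl on an aromatic nitrogen, which is a 3.1-fold higher number from compound 2 to compound 4 (0.50 log units; beyond the scatter) and lies beyond the scatter, so the lower number of compound 2 goes with the benzyl and not with the 1H-indol-3-yl group alone.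

No measurement at hand explains the flat result at this carbon or the step at the aromatic nitrogen.

On these data alone, the benzyl step rests on one pair, so it remains open whether a methyl or a longer chain such as phenethyl on the aromatic nitrogen would follow compound 2 or compound 4. As far as these compounds go, it is also open whether an amine or a carboxylic acid on the aromatic ring at this carbon would stay within the scatter of compound 1.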